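A few compounds are considered here, and "the series" means these few. Any claim that something is new, unique, unknown or untested is made for them only; others in the source may bear on it.

Compound 3 `COc1ccc(Cn2c(C(=O)O)c(CNCc3cccc(OC)c3)c3ccc(C(F)F)cc32)cc1` sits at the edge of what a functional assay on Bel-7402 cells (Homo sapiens) for antiproliferative activity, read by MTT assay, with a stated time of 72 h (a lower number here means a stronger inhibitor, a higher number a weaker inhibitor), can report: in this assay compound 3 gives > 50000 nM, which is a limit of the assay and not a number. Compound 1 `COc1ccc(Cn2c(C(=O)O)c(CNC(=O)c3cccc(OC)c3)c3ccc(C)cc32)cc1` likewise gives only a limit in this assay, > 50000 nM. The shared limit is summarised by the limit of > 50000 nM in this assay, at which 2 of the 3 values shown sit. Compound 2 `COc1ccc(Cn2c(C(=O)O)c(CNCc3cccc(O)c3)c3ccc(C)cc32)cc1` gives 19800 nM in this assay. Among the measured compounds shown here, the single measured step, an at least 2.5-fold lower number from compound 1 to compound 2 (0.40 log units; beyond the scatter), lies on the amine nitrogen and therefore does not touch the place where compound 4 differs from compound 3. Compound 4 `COc1ccc(Cn2c(C(=O)O)c(CNCc3cccc(OC)c3)c3ccc(C)cc32)cc1` differs from compound 3 by methyl in place of difluoromethyl on an aromatic carbon. For the measured compounds named here, no measured step bears on this change, so no direction beyond the scatter can be drawn from the steps alone; the only number below the limit belongs to compound 2, which also carries a methyl at that position. Compound 4 is expected to give 40000 nM in this assay, within a range of 12000 nM to 120000 nM. That estimate means an expected step of an at least 1.2-fold lower number from compound 3 to compound 4 (0.09 log units; that floor lies within the scatter).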

Compound 4, half-maximal inhibitory concentration: 9830 nM
Beside the measured number, compound 4's estimate is 4.1-fold (0.61 log units) above it, and the stated range ends above it.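

In this assay, the change on the aromatic carbon now has a measured step of its own, the first to bear on this position: with methyl in place of difluoromethyl there is an at least 5.0-fold lower number from compound 3 to compound 4 (0.70 log units; beyond the scatter). On the amine nitrogen, 3-methoxybenzyl in place of (3-methoxyphenyl)carbonyl gives an at least 5.0-fold lower number from compound 1 to compound 4 (0.70 log units; beyond the scatter). Methyl in place of hydrogen on the oxygen on an aromatic ring gives a 2.0-fold lower number from compound 2 to compound 4 (0.30 log units; within the scatter), which does not separate the two.

From the compounds shown here alone, the values of compound 1 and compound 3 are limits and not numbers, so the full size of the steps from them stays unknown: the limit of > 50000 nM in this assay, at which 2 of the 4 values shown sit. Going by these compounds, what hydrogen, chlorine or trifluoromethyl on that aromatic carbon would give, and how far an ester in place of the carboxylic acid would carry, stays open.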